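Fluoro to methoxy on the fused ring of compound 2

A few compounds are considered here, and "the series" means these few. Any claim that something is new, unique, unknown or untested is made for them only; others in the source may bear on it.

Two amides of the shared core have been measured in an ADME assay on HEK-293T cells (Homo sapiens) for cytotoxicity, read by MTT assay, with a stated time of 72 h; on this read-out lower numbers stand for stronger inhibition and higher numbers for weaker inhibition. Compound 1 `COc1ccc2nc(NC(=O)c3cn(-c4ccccc4)nc3-c3ccc(Cl)cc3)sc2c1` gives 29600 nM. Compound 2 `COc1ccc(-c2nn(-c3ccccc3)cc2C(=O)Nc2nc3ccc(F)cc3s2)cc1` gives 15400 nM, which is the lower of the two numbers; the gap to compound 1 lies within the scatter, so no order between them can be read from these values. Compound 3 `COc1ccc(-c2nn(-c3ccccc3)cc2C(=O)Nc2nc3ccc(OC)cc3s2)cc1` is the next member to be measured in this assay. It differs from compound 2 in one place: methoxy in place of fluoro on an aromatic carbon. Going by the values given here, no measured pair carries this change, so the size of its effect is unknown from the numbers at hand. The expectation is a step from compound 2 to compound 3 of a 1.3-fold higher number from compound 2 to compound 3 (0.11 log units; within the scatter), not beyond the scatter in either direction. Compound 3 is therefore estimated at 20000 nM in this assay, with a range from 8000 nM to 50000 nM.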

Compound 3, half-maximal inhibitory concentration: > 50000 nM
Compound 3: a limit, no number; the forecaster's own chance of this, stated with the estimate: 15%; at least 2.5-fold (0.39 log units) between middle value and limit.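

In this assay compound 3 gives > 50000 nM, a limit of the assay and not a number: the limit of > 50000 nM in this assay, at which 1 of the 3 values shown sits.

Methoxy in place of fluoro at this position gives an at least 3.2-fold higher number from compound 2 to compound 3 (0.51 log units; beyond the scatter), the first step in the series that lies beyond the scatter, so the substituent on this fused ring can shift the read-out, and only the floor of that shift is known. Methoxy in place of chloro on an aromatic carbon gives an at least 1.6-fold higher number from compound 1 to compound 3 (0.22 log units; that floor lies within the scatter), and with that floor inside the scatter, no order between these two compounds can be read.

On these data alone, the full size of the step from fluoro to methoxy remains open. Also open, as far as these compounds go, is where an amine or a carboxylic acid at this position would fall relative to compound 2.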